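The source may report more compounds than this note shows. Statements on the series, on what has been measured and on what is new or still open speak of the compounds shown alone.

Measured compounds in an ADME assay on HCT-116 cells (Homo sapiens) for cytotoxicity, read by MTT assay, with a stated time of 72 h; on this read-out lower numbers stand for stronger inhibition and higher numbers for weaker inhibition:
compound 1 `Cc1ccc(N2C(=O)C/C(=C\c3cccc(C(=O)Nc4cccc(F)c4)c3)C2=O)cc1` gives > 100000 nM
compound 2 `CCCCCN1C(=O)C/C(=C\c2cccc(C(=O)Nc3cccc(F)c3)c2)C1=O` gives > 100000 nM
compound 3 `Cc1ccc(NC(=O)c2cccc(/C=C3\CC(=O)N(c4ccccc4)C3=O)c2)cc1` gives > 100000 nM

Each of these three values is a limit of the assay and not a number. Compound 1 stands at that limit, (the limit of > 100000 nM in this assay, at which 3 of the 3 values shown sit), so no number places it against the other two. Going by the values given here, the only step that can be read as a pair, a step that the two limits leave unreadable from compound 1 to compound 2, is left unreadable by the two limits and gives no size to compare. The pair of compound 1 and compound 3 differs elsewhere in the shared core and its values show nothing readable either.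

The change considered is ethyl in place of fluoro on an aromatic carbon, giving compound 4 `CCc1cccc(NC(=O)c2cccc(/C=C3\CC(=O)N(c4ccc(C)cc4)C3=O)c2)c1`. Among the compounds with values here, no measured step carries this change: the step from compound 1 to compound 2 concerns the amide-type nitrogen in a ring, and both measured pairs show only limits. Since everything measured sits at the limit, the expectation for compound 4 in this assay is no step beyond the scatter, with a good chance that the assay again reports only a limit. The step expected from compound 1 to compound 4 is estimated as a step that the limit leaves unreadable from compound 1 to compound 4. Compound 4 is estimated at 150000 nM, in the expected range 50000 nM to 500000 nM.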

Compound 4, half-maximal inhibitory concentration: 41500 nM
Beside the measured number, compound 4's estimate is 3.6-fold (0.56 log units) above it, and the stated range ends above it.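

In this assay, going by these compounds alone, ethyl in place of fluoro on an aromatic carbon gives an at least 2.4-fold lower number from compound 1 to compound 4 (0.38 log units; beyond the scatter), the first step that can be read. For compound 1, > 100000 nM is a limit of the assay and not a number, so the data fix only the direction of this step and a minimum for its size. The earlier compounds could not show that this position has any bearing on the read-out, and the change from 3-fluorophenyl to 3-ethylphenyl now shows that it does, with compound 4 the only one of the compounds shown that stands off the limit: the limit of > 100000 nM in this assay, at which 3 of the 4 values shown sit.

The compounds shown hold only fluoro and ethyl at this position, so it remains open whether a longer chain such as propyl, an amine or a carboxylic acid would move the number further in this assay. Also open, as far as these compounds go, is whether ethyl in this place gives a readable number when the amide-type nitrogen in the ring carries pentyl, as in compound 2, in place of 4-methylphenyl.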